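The source may hold more compounds than are shown below. What is called first, only, known or untested is meant among the compounds shown, and "the series" means these compounds.

The compounds here share the core of compound 1 `CCOC(=O)C1=Cc2ccccc2OC1(OCc1cn(-c2cccc(OC)c2)nn1)C(F)(F)F` and differ only in the group on an aromatic nitrogen of the five-membered ring with three nitrogens. In a functional assay on HeLa cells (Homo sapiens) for inhibition, read by MTT assay, with a stated time of 24 h (a higher number here means a weaker inhibitor, a lower number a stronger inhibitor), compound 1 gives only a limit of the assay, > 150000 nM. Compound 2 `CCOC(=O)C1=Cc2ccccc2OC1(OCc1cn(CC(=O)Nc2ccc(C)cc2)nn1)C(F)(F)F`, which carries a ((4-methylphenyl)carbamoyl)methyl group on that nitrogen, gives 67400 nM in this assay. Compound 3 `CCOC(=O)C1=Cc2ccccc2OC1(OCc1cn(-c2ccccc2)nn1)C(F)(F)F` carries a plain phenyl on that nitrogen. In this assay compound 3 also gives only a limit of the assay, > 150000 nM. Compound 3 therefore stands at the weak end of what is shown, at the limit of > 150000 nM in this assay, at which 2 of the 3 values shown sit, together with compound 1.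

Compound 4 `CCOC(=O)C1=Cc2ccccc2OC1(OCc1cn(CC(=O)Nc2ccccc2Br)nn1)C(F)(F)F` applies a change to compound 3 of the kind already seen between compound 1 and compound 2: ((2-bromophenyl)carbamoyl)methyl in place of phenyl on an aromatic nitrogen. Among the measured compounds shown here, two measured steps bear on this. The step of an at least 2.2-fold lower number from compound 1 to compound 2 (0.34 log units; beyond the scatter) went in the same direction as the change to compound 4, and the step of an at least 2.2-fold higher number from compound 2 to compound 3 (0.34 log units; beyond the scatter) went the opposite way; both were at least modest. An at least modest move toward a lower number is thus expected, namely an at least 2.1-fold lower number from compound 3 to compound 4 (0.33 log units; beyond the scatter). Compound 4 is estimated at 70000 nM, within a range from 20000 nM to 150000 nM.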

Compound 4, half-maximal inhibitory concentration: > 150000 nM
Compound 4 gave a limit, no number (the forecaster's own chance of this, stated with the estimate: 30%); middle value at least 2.1-fold (0.33 log units) away from the limit.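

In this assay, 2-bromophenyl in place of 4-methylphenyl on the amide-type nitrogen gives an at least 2.2-fold higher number from compound 2 to compound 4 (0.34 log units; beyond the scatter). The ((4-methylphenyl)carbamoyl)methyl group of compound 2 had suggested that this kind of chain might lower the number, but compound 4 shows that the chain alone does not ensure a measurable value, and that the ring on the amide-type nitrogen matters within this pair. Compound 4 gives only a limit of the assay, so its steps from compound 1 and from compound 3 cannot be read, and it sits with those two compounds: the limit of > 150000 nM in this assay, at which 3 of the 4 values shown sit.

The two rings on the amide-type nitrogen differ in both the substituent and its place on the ring, so the compounds shown leave open which of these two differences matters; 4-bromophenyl or 2-methylphenyl on that nitrogen would separate them. Also open, on these data alone, is whether a ring is needed there at all, and how a simple methyl group or a longer carbon chain on the amide-type nitrogen would compare with compound 2.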